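Swapping tert-butyl for fluoro: what to expect

The compounds below may be only part of what the source reports. "The series", "measured", "known", "first", "only" and "open" are said of these compounds alone.

Measured so far in an assay on liver for inhibition of sterol O-acyltransferase 1 (Rattus norvegicus), using microsomes; on this read-out lower numbers stand for stronger inhibition and higher numbers for weaker inhibition:
Compound 1 `Cc1cc(C(C)(C)C)c(OC(=O)NS(=O)(=O)N(CC2CCCO2)CC2CCCO2)c(C(C)(C)C)c1` gives 21000 nM.
Compound 2 `COC(=O)NS(=O)(=O)Nc1c(C(C)C)cccc1C(C)C` reaches only the assay limit, > 100000 nM.
Compound 3 `CC(C)c1cc(C(C)(C)C)cc(C(C)C)c1OC(=O)NS(=O)(=O)Oc1c(C(C)C)cccc1C(C)C` gives 8800 nM.

Of the two numbers, compound 3 stands lowest, which here means the stronger inhibition; compound 1 is the nearest, and the gap between them lies beyond the usual scatter. The result for compound 2 is a limit rather than a number, as the limit of > 100000 nM in this assay, at which 1 of the 3 values shown sits, records. Compound 4 `CC(C)c1cc(F)cc(C(C)C)c1OC(=O)NS(=O)(=O)Oc1c(C(C)C)cccc1C(C)C` has not yet been measured; it differs from compound 3 by fluoro in place of tert-butyl on an aromatic carbon. Going by the values given here, no pair of measured compounds differs in exactly this way, so the step must be judged from the change alone. A modest weakening is expected, with the step of a 2.0-fold higher number from compound 3 to compound 4 (0.31 log units; beyond the scatter) probably reaching beyond the scatter. Compound 4 is therefore estimated at 18000 nM, expected to fall within 5000 nM to 60000 nM.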

Compound 4, half-maximal inhibitory concentration: > 50000 nM
Compound 4: a limit, no number; the forecaster's own chance of this, stated with the estimate: 10%; at least 2.7-fold (0.44 log units) between middle value and limit.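

Putting fluoro in place of tert-butyl on this aromatic carbon, meta to two isopropyl groups, gives an at least 5.6-fold higher number from compound 3 to compound 4 (0.75 log units; beyond the scatter). The result for compound 4 is a limit, not a number: the limit of > 50000 nM in this assay, at which 1 of the 4 values shown sits.

Going by these compounds alone, this is the first sign that inhibition in this assay depends on the group at this position, as this single change is enough to weaken it beyond the scatter. One pair cannot show whether the loss of the tert-butyl carbons or the arrival of fluorine matters more. On these data alone, how a chloro or methoxy group would behave at this position also remains open.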